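The compounds below may be only part of what the source reports. "The series", "measured", "known", "first", "only" and "open" are said of these compounds alone.

Compound 1, `CC1(C)C[C@H](O)C[C@](C)(CNc2nc3ccccc3s2)C1`, is the starting point of the series. In an in vitro ADME assay on microsomes from liver (Mus musculus) for pharmacokinetics, tested at 1 uM (a higher number here means faster removal of the compound, a lower number slower removal), compound 1 gives 85.4 mL/min/kg. Compound 2, `CC1(C)C[C@H](O)C[C@](C)(CNc2nc3ccc(F)cc3s2)C1`, carries fluoro in place of hydrogen on an aromatic carbon; in this assay compound 2 gives 78.2 mL/min/kg, so the step of a 1.1-fold lower number from compound 1 to compound 2 (0.04 log units; within the scatter) is small. Compound 3, `CC1(C)C[C@H](O)C[C@](C)(CNc2cccc(S(N)(=O)=O)c2)C1`, has a different core; how the two cores differ is not broken down here. In this assay compound 3 gives 37.2 mL/min/kg, the lowest of the three numbers, with the gaps to compound 2 and compound 1 both beyond the scatter.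

Compound 4, `CC1(C)C[C@H](O)C[C@](C)(CNc2cc(F)cc(S(N)(=O)=O)c2)C1`, is not yet measured. It differs from compound 3 by fluoro in place of hydrogen on an aromatic carbon, the same kind of change as from compound 1 to compound 2, though the place is not the same: there the fluoro sat on a ring that is part of a fused system, meta and para to a fused ring, whereas here it sits meta to a large group, meta to a sulfamoyl group. Because the earlier step of a 1.1-fold lower number from compound 1 to compound 2 (0.04 log units; within the scatter) stayed within the scatter, a similarly small step a 1.1-fold lower number from compound 3 to compound 4 (0.04 log units; within the scatter) is expected. For compound 4 the clearance is estimated at 34 mL/min/kg, most likely between 20 mL/min/kg and 58 mL/min/kg.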

Compound 4, clearance: 42.3 mL/min/kg
Compound 4: middle estimate off by 1.2-fold (0.09 log units), on the low side, within the range that was stated.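

In this assay fluoro in place of hydrogen on an aromatic carbon gives a 1.1-fold higher number from compound 3 to compound 4 (0.06 log units; within the scatter) and so leaves no readable mark on clearance on this second core. Set beside the earlier step, the two results agree: the same change on two cores in this assay, a 1.1-fold lower number (0.04 log units; within the scatter) from compound 1 to compound 2 and a 1.1-fold higher number (0.06 log units; within the scatter) from compound 3 to compound 4, 1.2-fold (0.09 log units) apart, within the scatter of two such steps. In these two pairs, then, the change carried from one core to the other without a readable effect on clearance, but this does not show that it would do so on any further core or at any other place on the ring, and the fluoro does not sit at a matching place in the two pairs.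

The compounds shown leave open whether a larger group at the place taken by fluoro in compound 4, such as chloro, methoxy or an amine, would give a step beyond the scatter. They also leave open how clearance would respond on the core of compound 3 if a carboxylic acid or an amide stood in place of the sulfamoyl group.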